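The compounds below may be only part of what the source reports. "The series", "measured", "known", "first", "only" and "open" are said of these compounds alone.

Compound 1, `Cn1cc(SCc2nnc(SCc3cc(C(F)(F)F)ccc3Cl)n2-c2c(Cl)cccc2Cl)c2ccccc21`, gives 53800 nM in a toxicity assay on HEK-293T cells (Homo sapiens) for cytotoxicity, read by CCK-8 assay, with a stated time of 48 h; on this read-out lower numbers stand for higher toxicity in this test and higher numbers for lower toxicity in this test.
Compound 2, `Cn1cc(SCc2nnc(SCc3cc(Cl)ccc3F)n2-c2c(Cl)cccc2Cl)c2ccccc21`, reaches only the limit > 100000 nM in this assay, which is a boundary of the test and not a number.
Compound 3, `Cn1cc(SCc2nnc(SCc3c(F)cccc3Cl)n2-c2c(Cl)cccc2Cl)c2ccccc21`, likewise reaches only the limit > 100000 nM in this assay.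

From the compounds shown here alone, compound 3 therefore stands at the limit of > 100000 nM in this assay, at which 2 of the 3 values shown sit, so its exact position is unknown. Compound 4, `Cn1cc(SCc2nnc(SCc3ccc(Cl)c(F)c3)n2-c2c(Cl)cccc2Cl)c2ccccc21`, differs from it by 4-chloro-3-fluorophenyl in place of 2-chloro-6-fluorophenyl on a saturated chain carbon bound to a sulfur. Changes at this same position gave an at least 1.8-fold higher number from compound 1 to compound 2 (0.26 log units; that floor lies within the scatter) and an at least 1.8-fold higher number from compound 1 to compound 3 (0.26 log units; that floor lies within the scatter), while a step that the two limits leave unreadable from compound 2 to compound 3. No change here has moved the number beyond the scatter, so no step beyond the scatter is expected for a number no higher from compound 3 to compound 4 (the limit leaves the size open). Compound 4 is therefore estimated at 100000 nM in this assay, with a range from 45000 nM to 220000 nM.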

Compound 4, half-maximal cytotoxic concentration: > 100000 nM
Compound 4: only a limit was reported; the forecaster's own chance of this, stated with the estimate: 65%; the middle value lies on the limit itself.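

Compound 4 carries 4-chloro-3-fluorophenyl, a third arrangement of the same chlorine and fluorine on the phenyl group, and its > 100000 nM in this assay is again a limit, not a number. Against the 2-chloro-5-(trifluoromethyl)phenyl compound, the data show an at least 1.8-fold higher number from compound 1 to compound 4 (0.26 log units; that floor lies within the scatter), while the steps among compound 2, compound 3 and compound 4 cannot be read. Three different arrangements now end at the same boundary: the limit of > 100000 nM in this assay, at which 3 of the 4 values shown sit.

Any order among compound 2, compound 3 and compound 4 stays hidden. From the compounds shown here alone, whether an amine or a carboxylic acid on this phenyl group, or a longer chain to the sulfur, would give a measurable number also stays open.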